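This account rests on a few compounds, and the source may have more. Where it says the series, first, only, none or still open, it means among the compounds named here.

Measured so far in an assay on HEK293 cells for agonist activity at Bile acid receptor (Homo sapiens); on this read-out lower numbers stand for an effect already at smaller amounts and higher numbers for an effect only at larger amounts of compound:
compound 1 `O=C(O)c1cccc([C@H]2C[C@@H](c3ccc(OCc4c(-c5c(Cl)cccc5Cl)noc4C4CC4)cc3Cl)C2)c1` — 92 nM
compound 2 `CC(C)n1nc(C(=O)O)cc1C1CC1c1ccc(OCc2c(-c3c(Cl)cccc3Cl)noc2C2CC2)cc1Cl` — 6 nM
compound 3 `O=C(O)c1cccc([C@H]2C[C@](OCCO)(c3ccc(OCc4c(-c5c(Cl)cccc5Cl)noc4C4CC4)cc3Cl)C2)c1` — 377 nM

Compound 2 gives the lowest number of the three; compound 1 sits at a clearly higher number and compound 3 higher still. Among the measured compounds shown here, the only single-point step measured so far, a 4.1-fold higher number from compound 1 to compound 3 (0.61 log units; beyond the scatter), concerns a different change at a different part of the shared core and does not bear on the step considered here.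

Compound 4 `Clc1cc(OCc2c(-c3c(Cl)cccc3Cl)noc2C2CC2)ccc1C1CC1c1ccc(-c2nnn[nH]2)nc1` differs from compound 2 in 6-(1H-tetrazol-5-yl)pyridin-3-yl in place of 3-carboxy-1-isopropyl-1H-pyrazol-5-yl on a saturated ring carbon. For the measured compounds named here, with no measured step on this kind of change, the expected step of a 3.3-fold higher number from compound 2 to compound 4 (0.52 log units; beyond the scatter) is taken as a modest increase in number, with a wide range around it. For compound 4 the estimate in this assay is 20 nM, with a range from 5 nM to 80 nM.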

Compound 4, half-maximal effective concentration: 111 nM
Beside the measured number, compound 4's estimate is 5.6-fold (0.74 log units) below it; the whole stated range lies below it.
By their numbers in this assay, from the lowest: compound 2; then compounds 1 and 4 (each within the scatter of the next); then compound 3.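

In this assay, 6-(1H-tetrazol-5-yl)pyridin-3-yl in place of 3-carboxy-1-isopropyl-1H-pyrazol-5-yl on a saturated ring carbon gives a 19-fold higher number from compound 2 to compound 4 (1.27 log units; beyond the scatter) as a large step. This place on the three-membered ring therefore does not treat the two groups alike, although both hold the same count of heavy atoms and of hydrogen-bond donors. Nothing at hand accounts for the difference.

On these data alone, whether the step follows the tetrazole, the pyridine ring or the isopropyl group stays open. A 6-carboxypyridin-3-yl group at this place would help separate these.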